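Phthalazine anilines: sulfamoyl to cyano swap

The source may hold more compounds than are shown below. What is called first, only, known or untested is meant among the compounds shown, and "the series" means these compounds.

Measured compounds:
- compound 1, `NS(=O)(=O)c1ccc(Nc2nncc3ccccc23)cc1`: 23 nM
- compound 2, `O=S(=O)(Nc1nccs1)c1ccc(Nc2nncc3ccccc23)cc1`: 12 nM

In a functional assay on UO-31 cells (Homo sapiens) for antiproliferative activity, read by sulforhodamine B assay, with a stated time of 72 h (a lower number here means a stronger inhibitor, a higher number a weaker inhibitor), compound 1 gives 23 nM and compound 2 gives 12 nM. On the numbers shown, compound 1 and compound 2 sit within the scatter of each other, as the step of a 1.9-fold lower number from compound 1 to compound 2 (0.28 log units; within the scatter) shows; that single step concerns only the substituent on the sulfonamide nitrogen.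

Compound 3, `N#Cc1ccc(Nc2nncc3ccccc23)cc1`, differs from compound 1 as cyano in place of sulfamoyl on an aromatic carbon. Within the data shown here, no measured step touches the sulfamoyl group itself, so the one step on record gives no direct guide to this change; the data simply lack a comparison of this kind. The sulfamoyl group of compound 1 is replaced by a smaller group with one hydrogen-bond acceptor and no donor, so some loss is plausible, but the direction is uncertain. For compound 3 in this assay the estimated value is 45 nM, with a range of 12 nM to 170 nM. This estimate means an expected step of a 2.0-fold higher number from compound 1 to compound 3 (0.29 log units; within the scatter).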

Compound 3, half-maximal inhibitory concentration: 2 nM
The estimate for compound 3 lay 23-fold (1.35 log units) above the measured number; measured number below the stated range.
By their numbers in this assay, from the lowest: compound 3; then compounds 2 and 1 (each within the scatter of the next).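

In this assay, among these compounds, the place on the aromatic carbon para to a large group proves far more responsive than the sulfonamide nitrogen: cyano in place of sulfamoyl gives a 12-fold lower number from compound 1 to compound 3 (1.06 log units; beyond the scatter), whereas the one earlier step stayed within the scatter. The sulfamoyl group is therefore not needed for a low number in this pair, since cyano, with 0 hydrogen-bond donors and only 2 heavy atoms, gives the lowest number of the three compounds. Nothing available bears on the reason for this step.

The compounds shown leave open whether the step is particular to cyano, or whether a carboxylic acid, a primary amide, a methyl group or a chlorine atom at the same place would give a similar number. They also leave open how a hydrogen atom at this place would compare with either group.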